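The compounds below may be only part of what the source reports. "The series", "measured", "known", "first", "only" and "open" are said of these compounds alone.

Going by the values given here, compound 2 (`COc1cc(-c2csc(NC(=O)C(=O)O)n2)on1`) gives 8 mg/kg in a functional assay on the whole organism with Rattus norvegicus as the target (on this read-out higher numbers stand for an effect only at larger amounts of compound and lower numbers for an effect already at smaller amounts), and holds the only single number so far. Compound 1 (`O=C(O)C(=O)Nc1nc(-c2cc(Cl)no2)cs1`) reads > 30 mg/kg in this assay and that is a limit of the assay, not a number. Methoxy in place of chloro on an aromatic carbon gave an at least 3.7-fold lower number from compound 1 to compound 2 (0.57 log units; beyond the scatter) and that step leans on the limit of > 30 mg/kg in this assay, at which 1 of the 3 values shown sits, as its starting point. Among the compounds with values here, compound 3 (`O=C(O)C(=O)Nc1nc(-c2cc(-c3ccccc3)no2)cs1`), with phenyl at the same place, gives 0.6 mg/kg; 2.4 mg/kg (2 entries) in this assay and both entries are lower numbers than the one of compound 2. Next comes compound 4 (`O=C(O)C(=O)Nc1nc(-c2cc(-c3c(F)cccc3Cl)no2)cs1`), with 2-chloro-6-fluorophenyl in place of methoxy on an aromatic carbon. Within the data shown here, no measured step covers this change directly. The nearest guide is compound 3 at 0.6 mg/kg; 2.4 mg/kg (2 entries) in this assay and it points to lower numbers. The expected move is a 6.7-fold lower number from compound 2 to compound 4 (0.82 log units; beyond the scatter) towards lower numbers and beyond the scatter. In this assay the estimate for compound 4 is 1.2 mg/kg with an expected range from 0.3 mg/kg to 5 mg/kg as the working span.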

Compound 4, dose for half-maximal effect: > 30 mg/kg
Compound 4 was reported as a limit (the forecaster's own chance of this, stated with the estimate: 5%); middle value at least 25-fold (1.39 log units) from the limit.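

Compound 4 reads > 30 mg/kg in this assay, which is a limit of the assay, and the step from compound 1 to compound 4 cannot be read, as both ends are limits. At this aromatic carbon, next to the ring nitrogen, 2-chloro-6-fluorophenyl in place of methoxy gave an at least 3.7-fold higher number from compound 2 to compound 4 (0.57 log units; beyond the scatter), so a six-membered aromatic ring here does not by itself bring lower numbers. Compound 3, with plain phenyl at the same place, gives 0.6 mg/kg; 2.4 mg/kg (2 entries) in this assay, so what the phenyl ring carries matters and not only the presence of the ring.

The compounds shown do not separate the chloro from the fluoro on the phenyl ring, and they give no single number for compound 4. As far as these compounds go, how an amine or a longer alkyl chain would read at this carbon also stays open.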